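The source may hold more compounds than are shown below. What is called first, only, known or untested is meant among the compounds shown, and "the series" means these compounds.

In a functional assay on MGC-803 cells (Homo sapiens) for cytotoxicity, read by MTT assay, with a stated time of 72 h (a lower number here means a stronger inhibitor, a higher number a weaker inhibitor), three compounds sharing one core have been measured so far. Compound 1 (`CC(C)=C1C(=O)N(c2ccc(Cl)cc2)N(c2ccc(Cl)cc2)C1=O`) gives 39000 nM, compound 2 (`O=C1C(=Cc2ccc(O)cc2)C(=O)N(c2ccc(Cl)cc2)N1c1ccc(Cl)cc1`) gives 19500 nM, and compound 3 (`O=C1C(=Cc2ccc(Br)cc2)C(=O)N(c2ccc(Cl)cc2)N1c1ccc(Cl)cc1`) gives 16900 nM. Compound 3 therefore lies within the scatter of compound 2, while compound 1 carries a higher number than compound 3, a gap beyond the scatter.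

The next compound to be tested is compound 4 (`COc1ccc(C=C2C(=O)N(c3ccc(Cl)cc3)N(c3ccc(Cl)cc3)C2=O)cc1`). It differs from compound 3 in a single place, with methoxy in place of bromo on an aromatic carbon, para to a large group: methoxy in place of bromo on an aromatic carbon.

Among the compounds with values here, one measured step bears directly on this change, as it also involves the bromo group on an aromatic carbon. That step, with bromo in place of hydroxy, is a 1.2-fold lower number from compound 2 to compound 3 (0.06 log units; within the scatter). Within the data shown here, it is a single pair, and no measured compound yet carries methoxy, so the evidence is thin. Even so, the only exchange of this kind seen in this assay stayed within the scatter, and no step beyond the scatter is expected here, in either direction. The expected change is a 1.1-fold higher number from compound 3 to compound 4 (0.03 log units; within the scatter). Compound 4 is estimated at 18000 nM, with an expected range from 9000 nM to 36000 nM.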

Compound 4, half-maximal inhibitory concentration: > 128000 nM
Compound 4 gave a limit, no number; the forecaster's own chance of this, stated with the estimate: 5%; middle value at least 7.1-fold (0.85 log units) away from the limit.
By their numbers in this assay, from the lowest: compounds 3, 2 and 1 (each within the scatter of the next, the first and the last beyond it). At a limit, above all of these: compound 4.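

In this assay compound 4 gives only a limit, not a number: the limit of > 128000 nM in this assay, at which 1 of the 4 values shown sits. Methoxy in place of bromo gives an at least 7.5-fold higher number from compound 3 to compound 4 (0.87 log units; beyond the scatter), so this place on the aromatic ring, which had shown only a 1.2-fold lower number from compound 2 to compound 3 (0.06 log units; within the scatter), turns out not to be indifferent to the group it carries. Methyl in place of hydrogen on the oxygen gives an at least 6.5-fold higher number from compound 2 to compound 4 (0.81 log units; beyond the scatter), so among these three compounds hydroxy and bromo read alike while methoxy stands apart, and the earlier agreement between compound 2 and compound 3 did not extend to compound 4.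

The compounds shown leave open whether this drop belongs to methoxy alone or also appears with other groups on the same carbon, such as an amine, an ethoxy group or a carboxylic acid. They also leave open how far past its limit compound 4 really lies, so both new steps are known from one side only and their true size remains undetermined.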